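Swapping a Pyridine Arm for a Cyclopropyl Arm

The source may report more compounds than this note shows. Statements on the series, on what has been measured and on what is new or still open speak of the compounds shown alone.

Three compounds share one core. Compound 1 `CS(=O)(=O)Nc1ccc2c(c1)S(=O)(=O)N=C(C1=C(O)C3CCCC3N(Cc3ccccn3)C1=O)N2` was tested in an ADME assay on Huh-7 cells (Homo sapiens) for cytotoxicity, with a stated time of 72 h; on this read-out higher numbers stand for lower toxicity in this test and lower numbers for higher toxicity in this test; there compound 1 gives > 33000 nM, which is a limit of the test rather than a number (the limit of > 33000 nM in this assay, at which 1 of the 3 values shown sits). Compound 2 `Cc1cc(CN2C(=O)C(C3=NS(=O)(=O)c4cc(NS(C)(=O)=O)ccc4N3)=C(O)[C@H]3CCC[C@H]32)ccc1F` in this assay gives > 1000 nM, again a limit (the limit of > 1000 nM in this assay, at which 1 of the 3 values shown sits). Compound 3 `CC(C)(C)CCN1C(=O)C(C2=NS(=O)(=O)c3cc(NS(C)(=O)=O)ccc3N2)=C(O)C2CCCCCCC21` gives "not determined" (no result reported) in this assay, leaving no figure. Compound 1 thus sits at the higher of the two limits, with no single number to set against it. Compound 4 `CS(=O)(=O)Nc1ccc2c(c1)S(=O)(=O)N=C(C1=C(O)C3CCCC3N(CCC3CC3)C1=O)N2` differs from compound 1 as follows: cyclopropylmethyl in place of pyridin-2-yl on a saturated chain carbon bound to an amide-type nitrogen in a ring. Within the data shown here, no measured pair differing in one place is available, and no step size is known. The expected step is a number no higher from compound 1 to compound 4 (the limit leaves the size open), no larger than the scatter. Compound 4 is estimated at 33000 nM, between 10000 nM and 100000 nM.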

Compound 4, half-maximal cytotoxic concentration: > 33000 nM
Compound 4: a limit, no number; the forecaster's own chance of this, stated with the estimate: 70%; the middle value sits exactly at the limit.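

No step can be read from compound 1 to compound 4, since each gives only a limit of the test, not a number: the limit of > 33000 nM in this assay, at which 2 of the 4 values shown sit.

The compounds shown leave open whether cyclopropylmethyl in place of pyridin-2-yl changes cytotoxicity at all.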